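The source may hold more compounds than are shown below. What is called first, only, known or untested is meant among the compounds shown, and "the series" means these compounds.

Measured compounds in an ADME assay (liver) for metabolic stability, with Liver microsome (Rattus norvegicus) as the target, using microsomes and NADPH, with a stated time of 30 min, tested at 1 uM; on this read-out higher numbers stand for fast clearance and lower numbers for slow clearance:
- Compound 1, `COc1cc(C(O)(C(F)(F)F)C(F)(F)F)cnc1N1CCN(S(=O)(=O)c2ccc(N)nc2)CC1`: compound 1 gives < 14 mL.min-1.g-1, which is a limit of the assay rather than a number.
- Compound 2, `Cn1cc(-c2cc(C(O)(C(F)(F)F)C(F)(F)F)cnc2N2CCN(S(=O)(=O)c3ccc(N)nc3)CC2)cn1`: compound 2 gives 44 mL.min-1.g-1.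
- Compound 3, `NC(=O)c1cccc(-c2cc(C(O)(C(F)(F)F)C(F)(F)F)cnc2N2CCN(S(=O)(=O)c3ccc(N)nc3)CC2)c1`: compound 3 gives 63 mL.min-1.g-1.

Among the two numbers shown, compound 2 sits lowest, with compound 3 nearest; the gap between them, a 1.4-fold higher number from compound 2 to compound 3 (0.16 log units; within the scatter), is within the scatter, so the two cannot be told apart. Both aryl compounds do differ from compound 1, whose result is a limit of < 14 mL.min-1.g-1 in this assay, at which 1 of the 3 values shown sits: the steps of an at least 3.1-fold higher number from compound 1 to compound 2 (0.49 log units; beyond the scatter) and an at least 4.5-fold higher number from compound 1 to compound 3 (0.65 log units; beyond the scatter) both lie beyond the scatter.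

Compound 4, `Nc1ccc(S(=O)(=O)N2CCN(c3ncc(C(O)(C(F)(F)F)C(F)(F)F)cc3-c3ccc4ocnc4c3)CC2)cn1`, is still to be measured. It differs from compound 2 in one place: 1,3-benzoxazol-5-yl in place of 1-methyl-1H-pyrazol-4-yl on an aromatic carbon.

The step that bears most directly on this change is the swap of one aryl group for another, a 1.4-fold higher number from compound 2 to compound 3 (0.16 log units; within the scatter), which stayed within the scatter. On that basis the expected step of a 1.4-fold higher number from compound 2 to compound 4 (0.13 log units; within the scatter) is small, with a slight lean toward a higher number. Compound 4 is therefore estimated at 60 mL.min-1.g-1, in the range 30 mL.min-1.g-1 to 130 mL.min-1.g-1.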

Compound 4, intrinsic clearance in microsomes: 120 mL.min-1.g-1
For compound 4 the middle estimate is 2.0-fold (0.30 log units) below the measured one, and the stated range covers the measured number.
By their numbers in this assay, from the lowest: compounds 2, 3 and 4 (each within the scatter of the next, the first and the last beyond it). At a limit, below all of these: compound 1.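

At this aromatic carbon, ortho to a large group, the earlier swap of one aryl group for another stayed within the scatter in this assay, yet 1,3-benzoxazol-5-yl in place of 1-methyl-1H-pyrazol-4-yl gives a step beyond it, a 2.7-fold higher number from compound 2 to compound 4 (0.44 log units; beyond the scatter). The aryl groups here are therefore not all interchangeable, although against 3-carbamoylphenyl the step stays within the scatter, a 1.9-fold higher number from compound 3 to compound 4 (0.28 log units; within the scatter). The step from methoxy, an at least 8.5-fold higher number from compound 1 to compound 4 (0.93 log units; beyond the scatter), gives only a lower bound, since its starting result is a limit: the limit of < 14 mL.min-1.g-1 in this assay, at which 1 of the 4 values shown sits.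

The compounds shown cannot separate the effect of the added carbon-only six-membered ring from that of the other differences between these groups. From the compounds shown here alone, it also remains open whether an amine or a short alkyl chain at this carbon would give numbers nearer to compound 1 or to the aryl compounds.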